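This account rests on a few compounds, and the source may have more. Where it says the series, first, only, none or still open, it means among the compounds named here.

Working notes on the series. In a functional assay on A549 cells (Homo sapiens) for antiproliferative activity, read by CCK-8 assay, with a stated time of 72 h (on this read-out higher numbers stand for weaker inhibition and lower numbers for stronger inhibition), compound 1 `O=C(Nc1cccc(-c2oc3cc(-c4ccc(F)cc4)ccc3c(=O)c2O)c1)c1ccc(Cl)cc1` gives 10800 nM. Going by the values given here, compound 2 `CCc1ccc(C(=O)Nc2cccc(-c3oc4cc(-c5ccc(F)cc5)ccc4c(=O)c3O)c2)cc1` gives 18500 nM in this assay; the single measured step, a 1.7-fold higher number from compound 1 to compound 2 (0.23 log units; within the scatter), is within the scatter, so on the numbers so far compound 2 cannot be separated from compound 1, the only other compound measured.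

Compound 3 `COc1cc(OC)cc(C(=O)Nc2cccc(-c3oc4cc(-c5ccc(F)cc5)ccc4c(=O)c3O)c2)c1` follows from compound 2 by 3,5-dimethoxyphenyl in place of 4-ethylphenyl on a carbonyl carbon. Among the compounds with values here, no measured step shares this change. Within the data shown here, the only step available, a 1.7-fold higher number from compound 1 to compound 2 (0.23 log units; within the scatter), exchanges one substituent on the phenyl attached to the carbonyl carbon and leaves the number within the scatter. Here the entering group brings hydrogen-bond acceptors where the leaving group had none, and the data offer no precedent for that, so no step beyond the scatter is expected in this assay in either direction, with a wide range to reflect the missing precedent. The estimate for compound 3 in this assay is 15000 nM, with a range from 5000 nM to 45000 nM, meaning an expected step of a 1.2-fold lower number from compound 2 to compound 3 (0.09 log units; within the scatter).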

Compound 3, half-maximal inhibitory concentration: 2390 nM
Compound 3: the middle estimate sits 6.3-fold (0.80 log units) above what was measured; measured number outside the range, below it.
By their numbers in this assay, from the lowest: compound 3; then compounds 1 and 2 (each within the scatter of the next).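

The phenyl on the carbonyl carbon is not indifferent in this assay: the exchange of chloro for ethyl gave no separable change, but 3,5-dimethoxyphenyl gives a 7.7-fold lower number from compound 2 to compound 3 (0.89 log units; beyond the scatter) and a 4.5-fold lower number from compound 1 to compound 3 (0.66 log units; beyond the scatter). Both steps run in the same direction and lie beyond the scatter, so compound 3 stands apart from the other two compounds, which remain within the scatter of each other. Nothing in hand bears on the reason for this separation, and the change alters several things at once: the substituents, their number and their places on the ring, with 2 hydrogen-bond acceptors entering where 4-ethylphenyl had none.

The compounds shown leave open whether the oxygen atoms or the places of the substituents on the ring carry the step, a question that 3,5-dimethylphenyl, 3-methoxyphenyl and 4-methoxyphenyl at the same carbonyl carbon would separate. They also leave open how far this position tolerates other kinds of group, such as an amine or a carboxylic acid on the phenyl, and whether the step holds with the 4-fluorophenyl on the shared core exchanged.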